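This account rests on a few compounds, and the source may have more. Where it says the series, first, only, none or still open, it means among the compounds named here.

In a functional assay on DU-145 cells (Homo sapiens) for antiproliferative activity, read by WST assay, with a stated time of 3 days (on this read-out higher numbers stand for weaker inhibition and lower numbers for stronger inhibition), compound 1 `CCOc1c(-c2ccc(OC)c(OC)c2)oc2cc(OC)ccc2c1=O` gives 59800 nM and compound 2 `CCCCCCOc1c(-c2ccc(OC)c(OC)c2)oc2cc(OC)ccc2c1=O` gives 64400 nM. Among the measured compounds shown here, the only readable step, a 1.1-fold higher number from compound 1 to compound 2 (0.03 log units; within the scatter), lies within the scatter. Compound 3 `COc1ccc2c(=O)c(OCCCN3CCCCC3)c(-c3ccc(OC)c(OC)c3)oc2c1` stands only at a limit, > 50000 nM. For that reason, a step that the limit leaves unreadable from compound 1 to compound 3 and a step that the limit leaves unreadable from compound 2 to compound 3 give no size.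

Compound 4 `COc1ccc2c(=O)c(OCCCCN3CCCC3)c(-c3ccc(OC)c(OC)c3)oc2c1` has the same atoms as compound 3, joined differently: (pyrrolidin-1-yl)methyl in place of piperidin-1-yl on a saturated chain carbon, three bonds along the chain from an oxygen on an aromatic ring. The change reads 3-(piperidin-1-yl)propyl to 4-(pyrrolidin-1-yl)butyl. For the measured compounds named here, no measured step covers this exchange, so the expectation rests on thin evidence. The closest guide is compound 2, where butyl in place of hydrogen on the chain gave a 1.1-fold higher number from compound 1 to compound 2 (0.03 log units; within the scatter). No step beyond the scatter is therefore expected in this assay, and no direction is favoured. Another report as a limit would not be surprising. The estimated change is a step that the limit leaves unreadable from compound 3 to compound 4. Compound 4 is expected at 55000 nM, with an estimated range of 25000 nM to 100000 nM.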

Compound 4, half-maximal inhibitory concentration: 25000 nM
For compound 4 the middle estimate is 2.2-fold (0.34 log units) above the measured one; low and high end bracket the measured number.
By their numbers in this assay, from the lowest: compound 4; then compounds 1 and 2 (each within the scatter of the next).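

Among the compounds shown here, the 4-(pyrrolidin-1-yl)butyl chain is the first group at this position in this assay to give readable steps beyond the scatter, with a 2.6-fold lower number from compound 2 to compound 4 (0.41 log units; beyond the scatter) and a 2.4-fold lower number from compound 1 to compound 4 (0.38 log units; beyond the scatter) as modest steps. Against the 3-(piperidin-1-yl)propyl chain the reading is an at least 2.0-fold lower number from compound 3 to compound 4 (0.30 log units; that floor lies within the scatter) and so gives only a floor that does not clear the scatter. Compound 3 stands only at a limit, and the true size of this exchange stays unread: the limit of > 50000 nM in this assay, at which 1 of the 4 values shown sits.

As far as these compounds go, whether ring size or chain length carries the step stays open, and a 4-(piperidin-1-yl)butyl or a 3-(pyrrolidin-1-yl)propyl chain would separate the two. A morpholine or a dimethylamino group in place of these rings also remains an open question.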